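This account rests on a few compounds, and the source may have more. Where it says the series, first, only, none or still open, it means among the compounds named here.

The compounds here share one core and differ only in what sits on the carbonyl carbon. Compound 1 `COc1cc(-c2nn(-c3cccc(NC(=O)Nc4ccc(Cl)c(Cl)c4)c3)cc2-c2ccncc2)ccc1Cl`, compound 2 `COc1cc(-c2nn(-c3cccc(NC(=O)Nc4cccc(C(F)(F)F)c4)c3)cc2-c2ccncc2)ccc1Cl` and compound 3 `COc1cc(-c2nn(-c3cccc(NC(=O)c4ccc(Cl)c(C(F)(F)F)c4)c3)cc2-c2ccncc2)ccc1Cl` form the set. In a functional assay on OVCAR-3 cells (Homo sapiens) for inhibition, read by sulforhodamine B assay, with a stated time of 48 h (a lower number here means that less compound is tolerated, a higher number that more compound is tolerated), compound 1 gives > 50000 nM, which is a limit of the assay rather than a number. Among the measured compounds shown here, compound 2 gives 24700 nM in this assay, the only measured number in this set. For the measured compounds named here, the step of an at least 2.0-fold lower number from compound 1 to compound 2 (0.30 log units; that floor lies within the scatter) is the single measured step, and it rests on (the limit of > 50000 nM in this assay, at which 1 of the 2 values shown sits), so it says little about the size of any change. Compound 3 differs from compound 2 by 4-chloro-3-(trifluoromethyl)phenyl in place of (3-(trifluoromethyl)phenyl)amino on a carbonyl carbon. Going by the values given here, no measured step covers a change of this kind, so no shift beyond the scatter is expected in this assay, with some risk that only a limit is reported. Compound 3 is therefore estimated at 22000 nM, within a range from 6000 nM to 50000 nM. This estimate means an expected step of a 1.1-fold lower number from compound 2 to compound 3 (0.05 log units; within the scatter) for compound 3.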

Compound 3, concentration lethal to 50% of the cells: > 32500 nM
Compound 3 gave a limit, no number; the forecaster's own chance of this, stated with the estimate: 35%; middle value at least 1.4-fold (0.16 log units) away from the limit.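

The earlier compounds shown here kept an amino group on the carbonyl carbon and varied only the ring it carries, whereas in compound 3 a 4-chloro-3-(trifluoromethyl)phenyl group sits on that carbon directly, with the amino group and its hydrogen-bond donor gone. In this assay this gives an at least 1.3-fold higher number from compound 2 to compound 3 (0.11 log units; that floor lies within the scatter), so the swap shows no drop in the number, but it does not show a real rise either. Compound 3 gives only a limit of the assay, not a number: the limit of > 32500 nM in this assay, at which 1 of the 3 values shown sits.

Going by these compounds, the step between compound 1 and compound 3 cannot be read, and the true size of the step from compound 2 stays unknown. Also open, on these data alone, is whether a morpholine on the carbonyl carbon, in place of either group, would give a measurable number in this assay.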